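This account rests on a few compounds, and the source may have more. Where it says the series, first, only, none or still open, it means among the compounds named here.

This set is about a physicochemical assay for lipophilicity (a higher number here means a more lipophilic compound, a lower number a more polar compound), and how one small change in a side ring moves it. Compound 1 has the structure `C[C@H]1CC[C@@H]2[C@@H](OC(=O)[C@]23CC(c2ccc(Cl)cc2)=NO3)[C@]2(C)C(=O)C=C[C@@]12O`, and in this assay compound 1 gives 2.09. Compound 2, `C[C@H]1CC[C@@H]2[C@@H](OC(=O)[C@]23CC(c2ccc(F)cc2)=NO3)[C@]2(C)C(=O)C=C[C@@]12O`, differs from compound 1 in one place: fluoro in place of chloro on an aromatic carbon. In this assay compound 2 gives 1.58, so this change made a number 0.51 log units lower from compound 1 to compound 2 (beyond the scatter). Compound 3, `C[C@H]1CC[C@@H]2[C@@H](OC(=O)[C@]23CC(c2cccc(Cl)c2)N(c2ccccc2)O3)[C@]2(C)C(=O)C=C[C@@]12O`, rests on a different core; the difference between the core of compound 3 and the core of compound 1 is not broken down here. In this assay compound 3 gives 3.87, the highest of the three measured numbers. Compound 4, `C[C@H]1CC[C@@H]2[C@@H](OC(=O)[C@]23CC(c2cccc(F)c2)N(c2ccccc2)O3)[C@]2(C)C(=O)C=C[C@@]12O`, has not yet been measured. It differs from compound 3 by the same kind of change as that from compound 1 to compound 2: fluoro in place of chloro on an aromatic carbon. The surroundings of the place are not the same word for word: in compound 1 the group sits para to a large group, in compound 3 it sits meta to a large group, so the two changes are of the same kind rather than the same. The step from compound 3 to compound 4 is expected to be about as large as the measured one, a number 0.50 log units lower from compound 3 to compound 4 (beyond the scatter), because a number 0.51 log units lower from compound 1 to compound 2 (beyond the scatter) was seen for the same kind of change made on compound 1. In this assay compound 4 is therefore estimated at 3.37, with an expected range from 3 to 3.7.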

Compound 4, partition coefficient: 3.35
Beside the measured number, compound 4's estimate is 0.02 log units above it; measured number inside the range.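

In this assay, putting fluoro in place of chloro gave a number 0.52 log units lower from compound 3 to compound 4 (beyond the scatter), which is close in size to a number 0.51 log units lower from compound 1 to compound 2 (beyond the scatter), so on these two cores the change carried over in the same direction and by almost the same amount. Among the compounds shown here, this rests on only two pairs, and those pairs differ both in the core and in where the group sits on the ring (meta to a large group in compound 4), so they cannot separate the role of the core from the role of the place, and they do not show that the step would keep this size on a third core. Nothing measured here explains why the two steps came out so alike.

The compounds shown carry only chloro or fluoro in this place, so it remains open how an amine, a nitrile or a methoxy group there would move the number. Also open, on these data alone, is what a carboxylic acid or a longer chain in that place would do, and whether any such replacement would give steps of matching size on both cores.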